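A Methoxy Group Enters the Pentyl Chain

The source may report more compounds than this note shows. Statements on the series, on what has been measured and on what is new or still open speak of the compounds shown alone.

In a functional assay on M21 cells (Homo sapiens) for antiproliferative activity, with a stated time of 48 h (on this read-out higher numbers stand for weaker inhibition and lower numbers for stronger inhibition), compound 1 (`CCCCCc1cccc(NC(=O)NCCCCl)c1`) gives 24000 nM, while compound 2 (`CCCCCc1cccc(NC(=O)NC(=O)CCl)c1`) gives 3500 nM. Compound 2 therefore holds the lower of the two numbers and is the stronger inhibitor of the pair. Going by the values given here, the only measured step, a 6.9-fold lower number from compound 1 to compound 2 (0.84 log units; beyond the scatter), is modest and places (chloromethyl)carbonyl in place of 3-chloropropyl on an amide-type nitrogen.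

Compound 3 (`CCCCC(OC)c1cccc(NC(=O)NC(=O)CCl)c1`) keeps that part of compound 2 and differs elsewhere: methoxy in place of hydrogen on a saturated chain carbon bound to an aromatic carbon and a saturated chain carbon. In words, methoxy stands in place of hydrogen on a saturated chain carbon bound to an aromatic carbon and a saturated chain carbon, turning pentyl into 1-methoxypentyl. Among the compounds with values here, no measured step touches this chain, so the one step available bears on the question only indirectly, as a sense of how far the numbers in this assay can move. The data give no firm direction. A small shift is expected, and the estimated change is a 1.1-fold higher number from compound 2 to compound 3 (0.06 log units; within the scatter). Compound 3 is estimated at 4000 nM, with an expected range from 1500 nM to 11000 nM.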

Compound 3, half-maximal inhibitory concentration: 4200 nM
Compound 3: the middle estimate sits 1.1-fold (0.02 log units) below what was measured; measured number inside the range.
By their numbers in this assay, from the lowest: compounds 2 and 3 (each within the scatter of the next); then compound 1.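

Methoxy in place of hydrogen on a saturated chain carbon bound to an aromatic carbon and a saturated chain carbon, which turns pentyl into 1-methoxypentyl, gives a 1.2-fold higher number from compound 2 to compound 3 (0.08 log units; within the scatter) in this assay and so leaves compound 3 indistinguishable from compound 2 on this read-out. Going by these compounds alone, this is the first measured step on the chain itself, and it shows that this carbon can carry a methoxy group, with the (chloromethyl)carbonyl part kept in place, without a difference beyond the scatter, whereas the one earlier step, made at the amide-type nitrogen, did lie beyond it. Nothing at hand offers an explanation for this result.

On these data alone, it remains open how the number would respond to a hydroxyl group or an ethoxy group on the same chain carbon, or to a chain longer or shorter than pentyl. As far as these compounds go, it also remains open whether 1-methoxypentyl would behave in the same way with the 3-chloropropyl group of compound 1 in place of the (chloromethyl)carbonyl group.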